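Swapping Ethyl for Cyclopentyl on a Piperazine Nitrogen

The compounds below may be only part of what the source reports. "The series", "measured", "known", "first", "only" and "open" are said of these compounds alone.

Three compounds have been measured in an assay on HEK293 cells for antagonist activity at Toll-like receptor 9 (Homo sapiens), read by spectrophotometry; a higher number here means a weaker inhibitor, a lower number a stronger inhibitor:

Compound 1 `CCN1CCN(CCCn2cnc3c(N4CCN(CC)CC4)nc(N)nc32)CC1`: 260 nM
Compound 2 `CCN1CCN(CCCn2cnc3c(N4CCN(CC)CC4)nc(NCc4ccc(OC)cc4)nc32)CC1`: 200 nM
Compound 3 `CCN1CCN(CCCn2cnc3c(N4CCN(CC)CC4)nc(NCc4ccc(F)cc4)nc32)CC1`: 470 nM

Compound 2 carries the smallest of the three numbers, but its separation from compound 1 is only a 1.3-fold lower number from compound 1 to compound 2 (0.11 log units; within the scatter), so those two cannot be told apart. Going by the values given here, the only step beyond the scatter is a 2.4-fold higher number from compound 2 to compound 3 (0.37 log units; beyond the scatter), and a 1.8-fold higher number from compound 1 to compound 3 (0.26 log units; within the scatter) again stays within it.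

Compound 4 `CCN1CCN(CCCn2cnc3c(N4CCN(C5CCCC5)CC4)nc(NCc4ccc(OC)cc4)nc32)CC1` differs from compound 2 by cyclopentyl in place of ethyl on an amine nitrogen in a ring. All three measured steps concern the group on the nitrogen of the aromatic ring at the other end of the shared core, and none touches the ring nitrogen that here exchanges ethyl for cyclopentyl. Among the compounds with values here, there is therefore no measured step that bears on this change, and the measured steps that exist are all small, the largest being a 2.4-fold higher number from compound 2 to compound 3 (0.37 log units; beyond the scatter). With nothing pointing in either direction, the expectation is a step of no change at the digits printed from compound 2 to compound 4 (within the scatter) in this assay, that is, nothing beyond the scatter. The expected value for compound 4 is 200 nM, with a likely range from 70 nM to 600 nM.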

Compound 4, half-maximal inhibitory concentration: 120 nM
The estimate for compound 4 lay 1.7-fold (0.22 log units) above the measured number; the measured number falls inside the stated range.
By their numbers in this assay, from the lowest: compounds 4, 2, 1 and 3 (each within the scatter of the next, the first and the last beyond it).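

In this assay, cyclopentyl in place of ethyl gives a 1.7-fold lower number from compound 2 to compound 4 (0.22 log units; within the scatter) and so the two compounds cannot be told apart. This is the only step shown at this ring nitrogen, and it adds something the earlier steps could not: the change from 4-ethylpiperazin-1-yl to 4-cyclopentylpiperazin-1-yl takes the group from two carbons with no ring to five carbons in a five-membered ring, with no shift beyond the scatter. No supporting measurement bears on why the number holds up with this larger group.

One step at one position still says little about how much room for variation this nitrogen really has, and a hydrogen, a methyl, a cyclohexyl, a phenyl or an acetyl group there could each tell a different story. From the compounds shown here alone, it also remains open whether the same exchange would read alike on the other 4-ethylpiperazin-1-yl group, the one at the end of the propyl chain, or in compounds carrying 4-fluorobenzyl or a plain hydrogen in place of 4-methoxybenzyl.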